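This account rests on a few compounds, and the source may have more. Where it says the series, first, only, none or still open, it means among the compounds named here.

Working notes on the series. Compound 1 `COc1cc(OC)cc(-c2cc3ccccc3c(-c3cccc(O)c3)n2)c1` gives 3870 nM in a functional assay on DU-145 cells (Homo sapiens) for cytotoxicity, read by CCK-8 assay and cell counting, with a stated time of 72 h; on this read-out higher numbers stand for weaker inhibition and lower numbers for stronger inhibition. Compound 2 `COc1cc(OC)cc(-c2cc3ccccc3c(-c3cccc(OC)c3)n2)c1` reaches only a limit of this assay, > 50000 nM. The change between them, (methyl in place of hydrogen on an oxygen on an aromatic ring), made a step of an at least 12-fold higher number from compound 1 to compound 2 (1.11 log units; beyond the scatter); that step runs into (the limit of > 50000 nM in this assay, at which 1 of the 3 values shown sits), so its true size is not known. Compound 3 `COc1ccc(-c2cc3cc(C)ccc3c(-c3cccc(O)c3)n2)cc1OC` gives 6510 nM; the difference between its core and the core of compound 1 is not broken down here. Compound 4 `COc1cccc(-c2nc(-c3ccc(OC)c(OC)c3)cc3cc(C)ccc23)c1` carries the same change, (methyl in place of hydrogen on an oxygen on an aromatic ring), on a place described in the same words. It is expected to follow the measured step, with a 9.2-fold higher number from compound 3 to compound 4 (0.96 log units; beyond the scatter) estimated from an at least 12-fold higher number from compound 1 to compound 2 (1.11 log units; beyond the scatter), and a result sitting at a limit of this assay is thought likely. Compound 4 is estimated at 60000 nM, within 25000 nM to 150000 nM.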

Compound 4, half-maximal inhibitory concentration: > 50000 nM
Compound 4 was reported as a limit; the forecaster's own chance of this, stated with the estimate: 65%; the middle value is on the limit's open side.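

The change from hydroxy to methoxy on the 3-hydroxyphenyl group again weakens inhibition on a second core, with an at least 7.6-fold higher number from compound 3 to compound 4 (0.88 log units; beyond the scatter). In this assay compound 4 sits at a limit of the assay, > 50000 nM, which is not a number, so the step gives only a lower bound on its size. The direction therefore carries over between these two cores, but whether the size carries over cannot be told: the same change on two cores in this assay, an at least 12-fold higher number (1.11 log units; beyond the scatter) from compound 1 to compound 2 and an at least 7.6-fold higher number (0.88 log units; beyond the scatter) from compound 3 to compound 4; the limit leaves it open whether they differ.

Open, going by these compounds, is whether the hydrogen on that oxygen is what matters, or whether an amine or a carboxylic acid in place of the hydroxy would also hold activity. Also open, on these data alone, is how a longer chain on that oxygen, such as ethyl, would read in this assay.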